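Dimethylamino for methylsulfanyl on a thiophene-bearing nucleoside

The source may hold more compounds than are shown below. What is called first, only, known or untested is meant among the compounds shown, and "the series" means these compounds.

Compound 1 `CN(C)c1ncnc2c1c(-c1ccoc1)cn2[C@@H]1O[C@H](CO)[C@@H](O)[C@H]1O`: in a functional assay on CEM-DNR-bulk cells (Homo sapiens), read by MTT assay, with a stated time of 72 h (on this read-out lower numbers stand for stronger inhibition and higher numbers for weaker inhibition), compound 1 gives > 20000 nM, which is a limit of the assay.
Compound 2 `CSc1ncnc2c1c(-c1ccoc1)cn2[C@@H]1O[C@H](CO)[C@@H](O)[C@H]1O`: in this assay compound 2 gives > 20000 nM, again a limit.
Compound 3 `CSc1ncnc2c1c(-c1cccs1)cn2[C@@H]1O[C@H](CO)[C@@H](O)[C@H]1O`: in this assay compound 3 gives > 20000 nM, also a limit.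

From compound 2 to compound 1 the change is dimethylamino in place of methylsulfanyl on an aromatic carbon, and it produced a step that the two limits leave unreadable from compound 2 to compound 1. The cores of compound 2 and compound 3 differ by thiophen-2-yl in place of furan-3-yl on an aromatic carbon, with a step that the two limits leave unreadable from compound 2 to compound 3. Compound 4 `CN(C)c1ncnc2c1c(-c1cccs1)cn2[C@@H]1O[C@H](CO)[C@@H](O)[C@H]1O` carries the same change as compound 1, now on the core of compound 3: dimethylamino in place of methylsulfanyl on an aromatic carbon. Within the data shown here, every value measured so far rests at the limit of > 20000 nM in this assay, at which 3 of the 3 values shown sit, so no step gives a readable size. The step that the limit leaves unreadable from compound 3 to compound 4 is expected to be unreadable as well, because compound 3 itself sits at the limit of > 20000 nM in this assay, at which 3 of the 3 values shown sit. Compound 4 is therefore expected to give 30000 nM, most likely between 10000 nM and 100000 nM.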

Compound 4, half-maximal inhibitory concentration: > 20000 nM
Compound 4: a limit, no number (the forecaster's own chance of this, stated with the estimate: 85%); the middle value lies beyond the limit too.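

In this assay compound 4 gives > 20000 nM, a limit of the assay, so neither its step from compound 3 nor its step from compound 1 can be read: the limit of > 20000 nM in this assay, at which 4 of the 4 values shown sit.

The compounds shown leave open whether either change, dimethylamino for methylsulfanyl or thiophen-2-yl for furan-3-yl, alters activity at all.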